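Compound 3 and its 3-chloro-4-fluorophenyl analogue, compound 4

The source may report more compounds than this note shows. Statements on the series, on what has been measured and on what is new or still open speak of the compounds shown alone.

In an ADME assay on the whole organism (Rattus norvegicus, strain Sprague-Dawley) for pharmacokinetics, using cassette dosing, at a dose of 1 mg/kg by the oral route (on this read-out higher numbers stand for higher oral bioavailability and lower numbers for lower oral bioavailability), three compounds have been measured. On one shared core, compound 1 (`O=C(c1cc(-c2ccc(=O)[nH]c2)on1)N1CCC(Cc2ccc(F)cc2)CC1`) gives 18.4% and compound 2 (`O=C(c1cc(-c2ccc(=O)[nH]c2)on1)N1CCC(Cc2ccc(Cl)cc2)CC1`) gives 9.3% in this measure. Compound 3 (`O=C(Nc1ccc2[nH]c(=O)oc2c1)C(=O)N1CCN(c2ccc(Cl)cc2)CC1`), built on a different core, gives 17.8% as its reading. That number lies within the usual scatter of both of the others, so compound 3 cannot be ranked against them.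

Compound 4 (`O=C(Nc1ccc2[nH]c(=O)oc2c1)C(=O)N1CCN(c2ccc(F)c(Cl)c2)CC1`) differs from compound 3 as follows: 3-chloro-4-fluorophenyl in place of 4-chlorophenyl on an amine nitrogen in a ring and so carries 3-chloro-4-fluorophenyl in place of 4-chlorophenyl on an amine nitrogen in a ring. Going by the values given here, only one measured step bears on this, and only loosely. It is a number 9.1 percentage points lower from compound 1 to compound 2 (within the scatter) for chloro in place of fluoro on an aromatic carbon, a step within the scatter and on the other core. It is also not the same change, since compound 4 keeps a chloro and gains a fluoro, and no such exchange has been measured on the core of compound 3. Going by that single small step, no change beyond the scatter is expected, and the estimated size is a number 1.2 percentage points higher from compound 3 to compound 4 (within the scatter) and no more than that. In this assay the estimate for compound 4 is an expected 19% with a likely range of 8% to 31% on repeated measurement.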

Compound 4, oral bioavailability: 24.6%
Beside the measured number, compound 4's estimate is 5.6 percentage points below it, and the stated range covers the measured number.
By their numbers in this assay, from the lowest: compounds 2, 3, 1 and 4 (each within the scatter of the next, the first and the last beyond it).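

In this assay, the exchange of 4-chlorophenyl for 3-chloro-4-fluorophenyl on an amine nitrogen in a ring gives a number 6.8 percentage points higher from compound 3 to compound 4 (within the scatter). Going by these compounds alone, this is the first measured change at this place on the core of compound 3, and it shows that adding one fluorine while keeping the chlorine does not shift the oral bioavailability reading beyond the usual scatter; the only earlier step was a different exchange on another core. No measured information here accounts for the size of this step or ties it to any property of the group.

Going by these compounds, because this single step stays inside the scatter, it remains open whether an amine, a carboxylic acid or a longer chain in place of 3-chloro-4-fluorophenyl on that amine nitrogen would move the reading beyond the scatter. Also open, on these data alone, is whether the same exchange would read alike on the core of compound 1, where the halogen-bearing aromatic ring is attached differently.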